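From iodo to ethynyl on a shared core

The source may report more compounds than this note shows. Statements on the series, on what has been measured and on what is new or still open speak of the compounds shown alone.

Values measured in a functional assay on NCI-H522 cells (Homo sapiens) for cytotoxicity, with a stated time of 3 days (a lower number here means a stronger inhibitor, a higher number a weaker inhibitor), are as follows.
- Compound 1 `C=Cc1nc2ccccc2n1C` gives 2340 nM
- Compound 2 `Cn1c(I)nc2ccccc21` gives 1020 nM
- Compound 3 `C#Cc1nccs1` gives > 40000 nM, which is a limit of the assay

Of the two actual numbers, compound 2 has the lower, 1020 nM, and compound 1 is its nearest neighbour. Going by the values given here, the value of compound 3 is a limit and not a number, so it offers no measured step.

The next compound to consider is compound 4 `C#Cc1nc2ccccc2n1C`, which has ethynyl in place of iodo on an aromatic carbon, between two ring nitrogen atoms. The counted difference is ethynyl in place of iodo on an aromatic carbon. Among the compounds with values here, compound 3 also carries ethynyl, but its core differs from that of compound 2, and no step links them.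

Within the data shown here, only one measured step bears on this carbon, a 2.3-fold lower number from compound 1 to compound 2 (0.36 log units; beyond the scatter), and it is modest. That single step is a thin guide, and it gives no firm direction for ethynyl. A change of similar or smaller size is therefore expected in this assay, with a slightly higher number more likely than a lower one. The estimated step is a 1.3-fold higher number from compound 2 to compound 4 (0.11 log units; within the scatter), so no clear shift beyond the scatter is expected. Compound 4 is expected at 1300 nM, with an estimated range from 300 nM to 6000 nM.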

Compound 4, half-maximal inhibitory concentration: 8140 nM
Beside the measured number, compound 4's estimate is 6.3-fold (0.80 log units) below it; measured number above the stated range.
By their numbers in this assay, from the lowest: compound 2; then compound 1; then compound 4. At a limit, above all of these: compound 3.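

In this assay, going by these compounds alone, the group on this aromatic carbon, between two ring nitrogen atoms, proved to matter more than the one earlier step could show: the exchange of iodo for ethynyl gives an 8.0-fold higher number from compound 2 to compound 4 (0.90 log units; beyond the scatter) and so exceeds the earlier 2.3-fold lower number from compound 1 to compound 2 (0.36 log units; beyond the scatter) in size. Ethynyl also falls behind vinyl, with a 3.5-fold higher number from compound 1 to compound 4 (0.54 log units; beyond the scatter) on the same core, which places the three groups in the order iodo, vinyl, ethynyl from the lowest number to the highest, each step beyond the scatter. Nothing shown here accounts for this order, or for the gap between two carbon groups that differ in their bond to the ring-attached carbon.

What the compounds leave open is whether other groups on this carbon, such as bromo, an amine, a carboxylic acid or a longer chain, would fall inside or outside the span set by iodo and ethynyl. From the compounds shown here alone, it also remains open whether the same order of the three groups would hold on a different core, since all of these steps rest on the one shared core.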